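The source may report more compounds than this note shows. Statements on the series, on what has been measured and on what is new or still open speak of the compounds shown alone.

Working notes on the series, cytotoxicity set

Three members have been measured so far in a functional assay on Malme-3M cells (Homo sapiens) for cytotoxicity, read by sulforhodamine B assay, with a stated time of 48 h; a higher number here means a weaker inhibitor of growth, a lower number a stronger inhibitor of growth. Compound 1 `COc1ccc(-c2cs/c(=N\NC(=O)c3ccc(O)cc3)n2-c2ccc(OC)cc2OC)cc1` gives 64600 nM in this assay. Compound 2 `O=C(c1ccc(O)cc1)n1nc(-c2c(Cl)cccc2Cl)sc1=S` gives 49000 nM in this assay. Compound 3 `Cc1ccc(-c2cs/c(=N\NC(=O)c3ccc(O)cc3)n2-c2c(C)cccc2C)cc1` gives 85100 nM in this assay. On these numbers compound 1 has the second highest value of the three; its gap to compound 3 lies within the usual scatter, and so does its gap to compound 2, so no order among the three can be read from the data. Compound 2 carries a different core from the other two, and no single-point change links any two of the measured compounds.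

Compound 4 `COc1ccc(-n2c(-c3ccc(Cl)cc3)cs/c2=N\NC(=O)c2ccc(O)cc2)c(OC)c1` is the next member to be tested. It differs from compound 1 in one place: chloro in place of methoxy on an aromatic carbon, para to a large group. Going by the values given here, no measured pair differs in just this way, so there is no measured step to set the size. Given that all three measured values fall in one narrow band, the step from compound 1 to compound 4 is expected to be a 1.2-fold lower number from compound 1 to compound 4 (0.07 log units; within the scatter), none beyond the scatter. Compound 4 is therefore estimated at 55000 nM, within a range of 25000 nM to 120000 nM.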

Compound 4, concentration for total growth inhibition: 91200 nM
The estimate for compound 4 lay 1.7-fold (0.22 log units) below the measured number; the range from low to high includes it.
By their numbers in this assay, from the lowest: compounds 2, 1, 3 and 4 (each within the scatter of the next).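

In this assay the series now has its first pair that differs in one place, and it reads a 1.4-fold higher number from compound 1 to compound 4 (0.15 log units; within the scatter). At this place, on an aromatic carbon para to a large group, 4-methoxyphenyl gives way to 4-chlorophenyl with a step that stays inside the scatter, so no order between the two compounds can be read, and this one pair shows no sign that the read-out depends on which of these two groups is present. No measurement of any other kind bears on this step, and nothing can be said about what lies behind it.

Still open, as far as these compounds go, is whether the same flat reading holds for other groups at this place, such as an amine or a carboxylic acid, or only for methoxy and chloro. Also open, from the compounds shown here alone, is whether chloro in place of methoxy would give a step of like size with the other substituents on the shared core changed, as a single pair cannot set a trend for the series.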